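Adding a methoxy group to compound 2

This account rests on a few compounds, and the source may have more. Where it says the series, first, only, none or still open, it means among the compounds named here.

In a functional assay on NCI-H460 cells (Homo sapiens) for inhibition, read by CCK-8 assay, with a stated time of 72 h (a lower number here means a stronger inhibitor, a higher number a weaker inhibitor), compound 2 `Nc1ccccc1NC(=O)c1ccc(CNC(=O)c2n[nH]cc2NC(=O)c2ccccc2)cc1` gives 6320 nM. Compound 1 `Nc1ccccc1NC(=O)c1ccc(CNC(=O)c2n[nH]cc2NC(=O)c2ccccc2Cl)cc1` gives 6360 nM and compound 3 `O=C(NO)c1ccc(CNC(=O)c2n[nH]cc2NC(=O)c2c(Cl)cccc2Cl)cc1` gives 10600 nM, so compound 2 sits within the usual scatter of both. Compound 4 `COc1ccccc1C(=O)Nc1c[nH]nc1C(=O)NCc1ccc(C(=O)Nc2ccccc2N)cc1` differs from compound 2 by methoxy in place of hydrogen on an aromatic carbon, ortho to a large group. Going by the values given here, one measured step touches that ring, a 1.0-fold lower number from compound 1 to compound 2 (0.00 log units; within the scatter), with hydrogen in place of chloro, and it lies within the scatter. Among the compounds with values here, no measured compound carries methoxy, so this is thin evidence, and no shift beyond the scatter is expected in this assay. The expected step is a 1.0-fold higher number from compound 2 to compound 4 (0.01 log units; within the scatter). For compound 4 the estimated value is 6500 nM, with an expected range of 3000 nM to 14000 nM.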

Compound 4, half-maximal inhibitory concentration: 7350 nM
Beside the measured number, compound 4's estimate is 1.1-fold (0.05 log units) below it, and the stated range covers the measured number.
By their numbers in this assay, from the lowest: compounds 2, 1, 4 and 3 (each within the scatter of the next).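

At this position, ortho to a large group, methoxy is a third group read in this assay alongside hydrogen and chloro. The reading gives a 1.2-fold higher number from compound 2 to compound 4 (0.07 log units; within the scatter) and a 1.2-fold higher number from compound 1 to compound 4 (0.06 log units; within the scatter) and, like the earlier swap of chloro for hydrogen, shows no change beyond the scatter among these three groups. No evidence is available to explain this result.

As far as these compounds go, whether an amine, a carboxylic acid or a longer chain at this position would also stay within the scatter remains open. So does whether methoxy would behave the same way elsewhere on this ring.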